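Triazole ethers on the shared core: chloro for fluoro amide

A few compounds are considered here, and "the series" means these few. Any claim that something is new, unique, unknown or untested is made for them only; others in the source may bear on it.

Compound 1 `CCOC(=O)C1=Cc2ccccc2OC1(OCc1cn(CC(=O)Nc2cccc(F)c2)nn1)C(F)(F)F` gives > 150000 nM in a functional assay on A549 cells (Homo sapiens) for inhibition, read by MTT assay, with a stated time of 24 h (a higher number here means a weaker inhibitor, a lower number a stronger inhibitor), which is a limit of the assay and not a number.
Compound 2 `CCCCCCCCn1cc(COC2(C(F)(F)F)Oc3ccccc3C=C2C(=O)OCC)nn1` gives > 150000 nM in this assay, again a limit of the assay.
Compound 3 `CCOC(=O)C1=Cc2ccccc2OC1(OCc1cn(-c2ccc(F)c([N+](=O)[O-])c2)nn1)C(F)(F)F` gives 11900 nM in this assay.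

For the measured compounds named here, compound 3 holds the only number in the set; the two other values are limits. The steps toward it are an at least 12-fold lower number from compound 1 to compound 3 (1.10 log units; beyond the scatter) and an at least 12-fold lower number from compound 2 to compound 3 (1.10 log units; beyond the scatter), both readable only as lower bounds because of the limit of > 150000 nM in this assay, at which 2 of the 3 values shown sit. The step between compound 1 and compound 2, a step that the two limits leave unreadable from compound 1 to compound 2, cannot be sized.

Compound 4 `CCOC(=O)C1=Cc2ccccc2OC1(OCc1cn(CC(=O)Nc2cccc(Cl)c2)nn1)C(F)(F)F` is not yet measured. Its change from compound 3 is ((3-chlorophenyl)carbamoyl)methyl in place of 4-fluoro-3-nitrophenyl on an aromatic nitrogen. This is close to a reversal of the step into compound 3 from compound 1, with chlorine in place of fluorine on the carbamoyl phenyl; that step was an at least 12-fold lower number from compound 1 to compound 3 (1.10 log units; beyond the scatter), so a rise of at least that size is expected for compound 4, most likely back to the limit. The step expected is a 13-fold higher number from compound 3 to compound 4 (1.10 log units; beyond the scatter). Compound 4 is expected to give about 150000 nM, within 40000 nM to 400000 nM, in this assay.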

Compound 4, half-maximal inhibitory concentration: 12800 nM
Estimate against measurement, compound 4: 12-fold (1.07 log units) above; the whole stated range lies above it.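

At the aromatic nitrogen, ((3-chlorophenyl)carbamoyl)methyl and 4-fluoro-3-nitrophenyl are not told apart in this assay, with a 1.1-fold higher number from compound 3 to compound 4 (0.03 log units; within the scatter), so an arm bearing a carbamoyl group is compatible with a measurable value here. The single change of chloro in place of fluoro on an aromatic carbon gives an at least 11-fold lower number from compound 1 to compound 4 (1.06 log units; beyond the scatter), so within this pair the halogen on the carbamoyl phenyl separates a measured value from a limit. (3-Chlorophenyl)carbamoyl in place of heptyl gives an at least 11-fold lower number from compound 2 to compound 4 (1.06 log units; beyond the scatter), and both of these last two sizes are lower bounds only, because one end of each is a limit: the limit of > 150000 nM in this assay, at which 2 of the 4 values shown sit.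

The step between compound 1 and compound 2 cannot be read. Also open, as far as these compounds go, is whether bromo or methyl in the place of chloro, or a carboxylic acid or an amine on the same arm, would retain the value of compound 4.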